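A few compounds are considered here, and "the series" means these few. Any claim that something is new, unique, unknown or untested is made for them only; others in the source may bear on it.

Measured so far:
Compound 1, `O=C(Nc1cc(C(F)(F)F)ccc1N1CCCC1)c1cccnc1`, is reported in a functional assay on Jurkat cells (Homo sapiens) for cytotoxicity, read by MTT assay, with a stated time of 48 h (on this read-out higher numbers stand for weaker inhibition and lower numbers for stronger inhibition), as "not active" (no number reported), with no number given.
Compound 2, `O=C(Nc1cc(C(F)(F)F)ccc1Nc1ccc(Br)cc1)c1cccnc1Cl`, in this assay gives 20600 nM.

Compound 2 thus holds the only number shown, and it is weak. Compound 3, `O=C(Nc1cc(C(F)(F)F)ccc1N1CCCC1)c1cccnc1Cl`, keeps the shared core of compound 2 and takes the change (pyrrolidin-1-yl in place of (4-bromophenyl)amino on an aromatic carbon). With this change compound 3 comes to resemble compound 1, which showed no activity, so a move toward weaker inhibition is expected, possibly to the point where the assay reports only a limit. For compound 3 the estimate is 45000 nM in this assay, within 15000 nM to 120000 nM. The expected step is a 2.2-fold higher number from compound 2 to compound 3 (0.34 log units; beyond the scatter).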

Compound 3, half-maximal inhibitory concentration: "not active" (no number reported)
For compound 3 the study gives words and no number, and the estimate cannot be compared.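

In this assay, among these compounds, compound 3 is reported only in words, so no step from compound 2 to compound 3 can be read. Nothing shown bears on this result. The compounds shown leave open how far compound 3 lies from compound 2 in strength.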